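Methoxy in place of trifluoromethyl on the fused ring

This account rests on a few compounds, and the source may have more. Where it says the series, first, only, none or still open, it means among the compounds named here.

In an assay on HEK293 cells for displacement of a labelled ligand from Urotensin-2 receptor (Homo sapiens), read by fluorescence, with a stated time of 90 min (on this read-out higher numbers stand for weaker inhibition and lower numbers for stronger inhibition), compound 2 `O=C(NC1CCN(Cc2ccc(OC3CCNCC3)c(Br)c2)CC1)c1cc2cc(C(F)(F)F)ccc2s1` gives 100 nM. Compound 1 `O=C(NC1CCN(Cc2ccc(OC3CCNCC3)c(Br)c2)CC1)c1cc2cc(F)ccc2s1` gives 53 nM in this assay, and the two numbers lie within the scatter of each other, as a 1.9-fold higher number from compound 1 to compound 2 (0.28 log units; within the scatter) shows. Compound 3 `COc1ccc2sc(C(=O)NC3CCN(Cc4ccc(OC5CCNCC5)c(Br)c4)CC3)cc2c1` differs from compound 2 by methoxy in place of trifluoromethyl on an aromatic carbon. Among the compounds with values here, no measured step covers a methoxy at this carbon; the one step there, a 1.9-fold higher number from compound 1 to compound 2 (0.28 log units; within the scatter), stayed within the scatter, so no step beyond the scatter is expected for compound 3 in this assay, with a 1.4-fold lower number from compound 2 to compound 3 (0.15 log units; within the scatter). Compound 3 is estimated at 70 nM, within 25 nM to 200 nM.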

Compound 3, half-maximal inhibitory concentration: 100 nM
Compound 3: middle estimate off by 1.4-fold (0.15 log units), on the low side; low and high end bracket the measured number.
By their numbers in this assay, from the lowest: compounds 1, 2 and 3 (each within the scatter of the next).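

In this assay methoxy, which brings a hydrogen-bond acceptor to this aromatic carbon, reads the same as trifluoromethyl (no change at the digits printed from compound 2 to compound 3 (within the scatter)) and as fluoro (a 1.9-fold higher number from compound 1 to compound 3 (0.28 log units; within the scatter)). Both steps stay within the scatter, so the three groups show no separation at this position. No measured evidence bears on this result. Open, from the compounds shown here alone, is whether an amine or a carboxylic acid at this carbon would stay at the same level. Going by these compounds, a longer chain, such as ethoxy in place of methoxy, is equally open.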